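This account rests on a few compounds, and the source may have more. Where it says the series, first, only, none or still open, it means among the compounds named here.

Compound 1, `COc1ccccc1/C=C/C(=O)OC/C=C/c1cc(OC)c(OC)cc1OC`, gives 100% in a functional assay on the whole organism (strain Kunming) with Mus musculus as the target, with a stated time of 0.5 h, at a dose of 100 mg/kg by the intraperitoneal route; a higher number here means a weaker effect of the compound at the dose given, a lower number a stronger effect.
Compound 2, `COc1cc(OC)c(OC)cc1/C=C/COC(=O)/C=C/c1ccc(OC)c(OC)c1`, gives 100%.
Compound 3, `COc1cc(OC)c(OC)cc1/C=C/COC(=O)/C=C/c1ccc(Br)cc1`, gives 100%.

The three measured compounds share one core and differ only in the group sitting on a double-bonded chain carbon bound to a double-bonded chain carbon. On the numbers shown, compound 3 stands level with compound 1 and compound 2: the steps of no change at the digits printed from compound 1 to compound 2 (within the scatter), no change at the digits printed from compound 1 to compound 3 (within the scatter) and no change at the digits printed from compound 2 to compound 3 (within the scatter) all stayed within the scatter of repeated measurements.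

Compound 4, `COc1cc(OC)c(OC)cc1/C=C/COC(=O)/C=C/c1ccccc1C(F)(F)F`, has not yet been measured. It differs from compound 3 in this way: 2-(trifluoromethyl)phenyl in place of 4-bromophenyl on a double-bonded chain carbon bound to a double-bonded chain carbon. All three measured steps bear on this change, since each of them also swaps the group at that same place, and none of them moved the read-out beyond the scatter. A step of the same kind, none beyond the scatter, is therefore expected from compound 3 to compound 4, namely no change at the digits printed from compound 3 to compound 4 (within the scatter). Compound 4 is estimated at 100%, with a range from 85% to 100%.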

Compound 4, a percentage reported as activity, at one dose (the size of the read-out at that dose, not a potency): 100%
Beside the measured number, compound 4's estimate shows no gap at the digits printed; low and high end bracket the measured number.
By their numbers in this assay, from the lowest: compounds 1, 2, 3 and 4 (each within the scatter of the next).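

In this assay, the new group leaves the read-out level, with no change at the digits printed from compound 3 to compound 4 (within the scatter), no change at the digits printed from compound 2 to compound 4 (within the scatter) and no change at the digits printed from compound 1 to compound 4 (within the scatter). The last of these steps is the closest comparison, since trifluoromethyl replaces methoxy on an aromatic carbon, so this position now holds a fluorine-bearing group as well as the methoxy and bromo groups, again with no step beyond the scatter. No measurement shown here explains why the read-out stays level at this position.

Going by these compounds, all four compounds carry a substituted phenyl group at this place, so it remains open whether a phenyl group bearing an amine or a carboxylic acid, or a longer chain in place of the phenyl group, would move the read-out. Nor do these compounds show whether any change to the shared core would give a lower number at this dose.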